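The source may hold more compounds than are shown below. What is called first, only, known or untested is meant among the compounds shown, and "the series" means these compounds.

Three bromo analogues of a shared core have been run in a toxicity assay on the whole organism (P388 cells) for cytotoxicity, with Mus musculus as the target, with a stated time of 9 days, at a dose of 30 mg/kg by the intraperitoneal route; on this read-out lower numbers stand for a stronger effect and higher numbers for a weaker effect at the one dose given. Compound 1 `CN(C)/N=N\c1ccnc2cc(Br)ccc12` gives -2.4% there. Compound 2 `CN(C)/N=N\c1ccnc2c(Br)cccc12` gives 4.8% in this assay. Compound 3 `CN(C)/N=N\c1ccnc2ccc(Br)cc12` gives 10% in this assay, the highest of the three numbers; its gap to compound 2 lies within the scatter, while its gap to compound 1 lies beyond it. Compound 4 `CN(C)/N=N\c1ccnc2ccc(Cl)cc12` is not yet measured; it differs from compound 3 by chloro in place of bromo on an aromatic carbon. Among the compounds with values here, no step between two measured compounds covers this exchange, so only the spread of the three values guides expectation. In this assay a step from compound 3 to compound 4 of no more than the scatter, in either direction, is expected. For compound 4 the estimate is 8%, within -10% to 25%. The expected step is a number 2 percentage points lower from compound 3 to compound 4 (within the scatter).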

Compound 4, a percentage reported as activity, at one dose (the size of the read-out at that dose, not a potency): -12.9%
Compound 4: the middle estimate sits 20.9 percentage points above what was measured; measured number below the stated range.
By their numbers in this assay, from the lowest: compound 4; then compounds 1, 2 and 3 (each within the scatter of the next, the first and the last beyond it).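

In this assay the position is sensitive to which halogen it carries: chloro in place of bromo gives a step beyond the scatter (a number 22.9 percentage points lower from compound 3 to compound 4 (beyond the scatter)). The three bromo analogues varied only the place of bromo, so they could not show this, and here it rests on a single pair. Nothing at hand explains the step. Open, from the compounds shown here alone, is whether chloro in place of bromo at the other two bromo positions gives a step of similar size. Also open, going by these compounds, is how a methoxy group or an amine would read at this position.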